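This account rests on a few compounds, and the source may have more. Where it says the series, first, only, none or still open, it means among the compounds named here.

Working notes, cytotoxicity series.

Measured so far:
- compound 1, `COc1ccc(OC)c(C2=C(c3cc(OC)c(OC)c(OC)c3)C(=O)CC2O[SiH2]C(C)(C)C)c1`: 9.5 ug/mL in an ADME assay on HEK293 cells (Homo sapiens) for cytotoxicity, read by MTT assay, with a stated time of 72 h; on this read-out lower numbers stand for stronger inhibition and higher numbers for weaker inhibition
- compound 2, `COc1ccc(C2=C(c3cc(OC)c(OC)c(OC)c3)C(=O)CC2O)cc1`: 10 ug/mL in this assay

Compound 2 holds the highest of the two numbers, but its nearest neighbour, compound 1, sits within the usual scatter of this kind of measurement, so the two cannot be told apart and no order between them is claimed. Within the data shown here, no pair of measured compounds differing in a single place is available, so no measured step informs the next move.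

Compound 3, `CCOC(=O)COc1ccc(C2=C(c3cc(OC)c(OC)c(OC)c3)C(=O)CC2O)cc1`, is still to be tested in this assay. Relative to compound 2 the difference is ethoxycarbonyl in place of hydrogen on a saturated chain carbon bound to an oxygen on an aromatic ring. The ethoxycarbonyl enters on a saturated chain carbon bound to an oxygen on an aromatic ring, so that a methoxy becomes a (ethoxycarbonyl)methoxy; the rest of the shared core is untouched.

Nothing among the two measured compounds bears on such a change, since compound 1 and compound 2 differ from each other in several places at once and yet read alike. The step of no change at the digits printed from compound 2 to compound 3 (within the scatter) is therefore expected to stay within the scatter, in no particular direction. Compound 3 is estimated at 10 ug/mL, with a range from 5 ug/mL to 22 ug/mL.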

Compound 3, half-maximal inhibitory concentration: > 100 ug/mL
Compound 3: no number, only a limit; the forecaster's own chance of this, stated with the estimate: 5%; middle value at least 10-fold (1.00 log units) from the limit.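

Ethoxycarbonyl in place of hydrogen on a saturated chain carbon bound to an oxygen on an aromatic ring, turning a methoxy into a (ethoxycarbonyl)methoxy, gives an at least 10-fold higher number from compound 2 to compound 3 (1.00 log units; beyond the scatter) in this assay, which on this read-out means weaker inhibition; this is the first single-place step in the series, and it shows that this position does not tolerate every change without effect on the read-out. Compound 3 gives > 100 ug/mL in this assay, which is a limit of the assay and not a number. The true size of the step therefore remains unknown, and only its direction and minimum are fixed, with the reading resting on this limit: the limit of > 100 ug/mL in this assay, at which 1 of the 3 values shown sits.

The compounds shown leave open whether the step belongs to the ester itself or to any growth of the methoxy, and a carboxylic acid in place of the ethyl ester, or a longer alkyl chain on the same oxygen, would help separate the two. Also open, going by these compounds, is whether the same change would carry over to the core of compound 1, which differs from compound 2 in several places.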